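The source may hold more compounds than are shown below. What is called first, only, known or untested is meant among the compounds shown, and "the series" means these compounds.

Measured so far:
compound 1 `CCOc1ccccc1N1CCN(CCCCn2nc(-c3ccc(C)cc3)c3ccccc3c2=O)CC1` gives 2.23 nM
compound 2 `Cc1ccc(-c2nn(CCCCN3CCN(c4cccc(C(F)(F)F)c4)CC3)c(=O)c3ccccc23)cc1` gives 112 nM
compound 3 `CCOc1ccccc1N1CCN(CCCCCCCn2nc(-c3ccc(C)cc3)c3ccccc3c2=O)CC1` gives 7.33 nM

All three values come from an assay on Cerebral cortex for displacement of a labelled ligand from Adrenergic receptor alpha-1 (Rattus norvegicus); a higher number here means a weaker inhibitor, a lower number a stronger inhibitor. Compound 1 and compound 2 share a core and differ in one place: 3-(trifluoromethyl)phenyl in place of 2-ethoxyphenyl on an amine nitrogen in a ring. That change gave a 50-fold higher number from compound 1 to compound 2 (1.70 log units; beyond the scatter), a large step toward weaker binding. Compound 3 differs from compound 1 in a way that is not broken down here, yet compound 3 still shows a low number in this assay.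

Compound 4 `Cc1ccc(-c2nn(CCCCCCCN3CCN(c4cccc(C(F)(F)F)c4)CC3)c(=O)c3ccccc23)cc1` is not yet measured. It differs from compound 3 by 3-(trifluoromethyl)phenyl in place of 2-ethoxyphenyl on an amine nitrogen in a ring, the same change seen between compound 1 and compound 2. Because a 50-fold higher number from compound 1 to compound 2 (1.70 log units; beyond the scatter) was large, compound 4 is expected to bind much more weakly than compound 3, with an estimated step of about a 48-fold higher number from compound 3 to compound 4 (1.68 log units; beyond the scatter). The estimate for compound 4 in this assay is 350 nM, expected to fall between 100 nM and 1200 nM.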

Compound 4, inhibition constant: 382 nM
Beside the measured number, compound 4's estimate is 1.1-fold (0.04 log units) below it, within the range that was stated.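

Placing 3-(trifluoromethyl)phenyl where 2-ethoxyphenyl stood on the ring amine nitrogen gave a 52-fold higher number from compound 3 to compound 4 (1.72 log units; beyond the scatter) in this assay. The change therefore carried over from one core to the other, with steps that cannot be told apart: the same change on two cores in this assay, a 50-fold higher number (1.70 log units; beyond the scatter) from compound 1 to compound 2 and a 52-fold higher number (1.72 log units; beyond the scatter) from compound 3 to compound 4, 1.0-fold (0.02 log units) apart, within the scatter of two such steps. This shows that the loss of binding repeated on these two cores in this one assay, but it does not explain why the number rises or show that the step would hold on any other core.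

The compounds shown leave open how other groups on that ring nitrogen, such as a plain phenyl or a 2-methoxyphenyl, would behave. They also leave open whether the step would persist on a core with a shorter chain.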